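Ethyl in place of cyano on a sulfonamide aryl ring

The compounds below may be only part of what the source reports. "The series", "measured", "known", "first", "only" and "open" are said of these compounds alone.

Of the compounds shown here, three of a shared core have been measured in a physicochemical assay for lipophilicity, at pH 7.4; on this read-out lower numbers stand for lower lipophilicity and higher numbers for higher lipophilicity. Compound 1 `Cc1cc(C(O)(C(F)(F)F)C(F)(F)F)ccc1N(CC(C)C)S(=O)(=O)c1ccc2c(c1)C(O)CC(C1CCOCC1)O2` gives 4.37, compound 2 `CCc1ccc(NS(=O)(=O)c2ccc3c(c2)C(O)CC(C2CCOCC2)O3)cc1` gives 2.59, and compound 3 `CC(C)CN(c1ccc(C#N)cc1)S(=O)(=O)c1ccc2c(c1)C(O)CC(C1CCOCC1)O2` gives 3.07. In this assay compound 3 stands second highest of the three, with compound 2 nearest, lower by a gap beyond the scatter, and compound 1 furthest, higher by a gap beyond the scatter.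

Compound 4 `CCc1ccc(N(CC(C)C)S(=O)(=O)c2ccc3c(c2)C(O)CC(C2CCOCC2)O3)cc1` differs from compound 3 in one place: ethyl in place of cyano on an aromatic carbon. Among the measured compounds shown here, no measured pair shows this change by itself. An upward step beyond the scatter is expected for compound 4, as a number 1.03 log units higher from compound 3 to compound 4 (beyond the scatter). Compound 4 is thus estimated at 4.1, within a range from 3.6 to 4.6.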

Compound 4, distribution coefficient: 4.12
The estimate for compound 4 lay 0.02 log units below the measured number; the measured number falls inside the stated range.
By their numbers in this assay, from the lowest: compound 2; then compound 3; then compounds 4 and 1 (each within the scatter of the next).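

In this assay, among the compounds shown here, ethyl in place of cyano on this aromatic carbon gives a number 1.05 log units higher from compound 3 to compound 4 (beyond the scatter), a large rise and the first reading of this change by itself. Isobutyl in place of hydrogen on the sulfonamide nitrogen can now also be read alone and gives a number 1.53 log units higher from compound 2 to compound 4 (beyond the scatter), likewise large. No evidence at hand bears on the cause of either step.

Going by these compounds, whether the ethyl-for-cyano step holds with hydrogen on the sulfonamide nitrogen remains open. So does what a carboxylic acid, an amine or a longer chain would give on this aromatic carbon.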